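A Methyl Added to the Aryl Ring of Compound 3

The source may report more compounds than this note shows. Statements on the series, on what has been measured and on what is new or still open speak of the compounds shown alone.

Compound 3 `O=C(NCCCCc1ccccc1)c1cccc(C2SCC(=O)N2c2ccccc2)c1` gives 73% in a functional assay on SJSA-1 cells (Homo sapiens) for inhibition, read by CCK-8 assay, with a stated time of 72 h, tested at 1 uM (on this read-out lower numbers stand for less inhibition and higher numbers for more inhibition at the one concentration tested (going by the name of the read-out)), the second highest of the three numbers measured. Compound 2 `COc1ccc(F)cc1N1C(=O)CSC1c1cccc(C(=O)NCCCCc2ccccc2)c1` gives 76%, a gap within the scatter, while compound 1 `COc1ccc(OC)c(N2C(=O)CSC2c2cccc(C(=O)NCCCCc3ccccc3)c2)c1` gives 48%, with the step of a number 25 percentage points higher from compound 1 to compound 3 (beyond the scatter) lying beyond it. The step to compound 4 `Cc1cccc(N2C(=O)CSC2c2cccc(C(=O)NCCCCc3ccccc3)c2)c1` is methyl in place of hydrogen on an aromatic carbon. The measured steps that bear on it all alter the same ring: a number 3 percentage points lower from compound 2 to compound 3 (within the scatter), a number 25 percentage points higher from compound 1 to compound 3 (beyond the scatter) and a number 28 percentage points higher from compound 1 to compound 2 (beyond the scatter). Trimming groups from that ring never lowered the number beyond the scatter, and a single methyl is a smaller change than any of these, so no step beyond the scatter is expected, a number 3 percentage points lower from compound 3 to compound 4 (within the scatter). Compound 4 is therefore estimated at 70%, between 52% and 85%.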

Compound 4, a percentage reported as inhibition, at one concentration (the size of the read-out at that concentration, not a potency): 84%
Estimate against measurement, compound 4: 14 percentage points below, and the stated range covers the measured number.
By their numbers in this assay, from the lowest: compound 1; then compounds 3, 2 and 4 (each within the scatter of the next, the first and the last beyond it).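

In this assay, within the data shown here, methyl on an aromatic carbon, meta to a large group, is the first single change on the bare phenyl ring to move the number beyond the scatter (a number 11 percentage points higher from compound 3 to compound 4 (beyond the scatter)), showing that adding to this ring can raise the number as well as trimming it. The 3-methylphenyl compound stays level with the fluoro-bearing ring (a number 8 percentage points higher from compound 2 to compound 4 (within the scatter)) and far exceeds the dimethoxy ring (a number 36 percentage points higher from compound 1 to compound 4 (beyond the scatter)). Nothing shown explains the gain from the methyl.

On these data alone, whether ethyl, chloro or an amine on that carbon would behave like methyl remains open.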